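Phenoxy for methoxy on a dichloro core: cytotoxicity outlook

The source may hold more compounds than are shown below. What is called first, only, known or untested is meant among the compounds shown, and "the series" means these compounds.

In an ADME assay on Raji cells (Homo sapiens) for cytotoxicity, read by luminescence, with a stated time of 72 h (on this read-out higher numbers stand for an effect only at larger amounts of compound and lower numbers for an effect already at smaller amounts), compound 1 `CCOC(=O)c1c(-c2cccc(OC)c2)[nH]c2cc(F)cc(F)c2c1=O` gives only a limit of the assay, > 21500 nM. Compound 2 `CCOC(=O)c1c(-c2cccc(Oc3ccccc3)c2)[nH]c2cc(F)cc(F)c2c1=O` differs from compound 1 by phenyl in place of methyl on an oxygen on an aromatic ring. In this assay compound 2 likewise reaches only a limit of the assay, > 21500 nM. The step that the two limits leave unreadable from compound 1 to compound 2 is therefore not readable. Compound 3 `CCOC(=O)c1c(-c2cccc(OC)c2)[nH]c2cc(Cl)c(Cl)cc2c1=O` also stands at a limit in this assay, > 21500 nM; the difference between its core and that of compound 1 is not broken down here. Every measured value sits at the limit of > 21500 nM in this assay, at which 3 of the 3 values shown sit. Compound 4 `CCOC(=O)c1c(-c2cccc(Oc3ccccc3)c2)[nH]c2cc(Cl)c(Cl)cc2c1=O` differs from compound 3 by phenyl in place of methyl on an oxygen on an aromatic ring, the same change as from compound 1 to compound 2, at a place described in the same words. The step from compound 3 to compound 4 is estimated as a step that the limit leaves unreadable from compound 3 to compound 4, because the limit of > 21500 nM in this assay, at which 3 of the 3 values shown sit, holds for every measured compound and the earlier step gave no readable size. Compound 4 is therefore expected to show 30000 nM in this assay, most likely again only as a limit.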

Compound 4, half-maximal effective concentration: > 21500 nM
Compound 4 ended at the assay's limit; the forecaster's own chance of this, stated with the estimate: 85%; the middle value lies beyond the limit too.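

In this assay compound 3 and compound 4 both sit at a limit, and the step between them cannot be read. The compounds shown leave open whether phenoxy for methoxy changes cytotoxicity at all on either core.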